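From Butoxy to Methyl: An Estimate for Compound 3

A few compounds are considered here, and "the series" means these few. Any claim that something is new, unique, unknown or untested is made for them only; others in the source may bear on it.

Compound 1, `CCOc1ccccc1C(=O)/C=C/c1ccc2ccccc2c1`: 60 nM
Compound 2, `CCCCOc1ccccc1C(=O)/C=C/c1ccc2ccccc2c1`: 700 nM

Both compounds were tested in a functional assay on MEC1 cells (Homo sapiens) for cytotoxicity, with a stated time of 48 h; on this read-out higher numbers stand for weaker inhibition and lower numbers for stronger inhibition. Compound 2 stands at the highest of the two numbers, with compound 1 as its nearest neighbour, and the step of a 12-fold higher number from compound 1 to compound 2 (1.07 log units; beyond the scatter) is large and beyond the scatter. Compound 3, `Cc1ccccc1C(=O)/C=C/c1ccc2ccccc2c1`, differs from compound 2 by methyl in place of butoxy on an aromatic carbon. Among the compounds with values here, the only measured step shows that lengthening the chain on the oxygen raised the number sharply, so removing the chain and its oxygen altogether is expected to move the number back down, though compound 1 offers no direct template for a methyl group. The author therefore expects a step of a 5.8-fold lower number from compound 2 to compound 3 (0.77 log units; beyond the scatter) and estimates compound 3 at 120 nM, within 30 nM to 500 nM.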

Compound 3, half-maximal inhibitory concentration: 6400 nM
Compound 3: the middle estimate sits 53-fold (1.73 log units) below what was measured; measured number above the stated range.
By their numbers in this assay, from the lowest: compound 1; then compound 2; then compound 3.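

In this assay, methyl in place of butoxy gave a 9.1-fold higher number from compound 2 to compound 3 (0.96 log units; beyond the scatter), and methyl in place of ethoxy gave a 110-fold higher number from compound 1 to compound 3 (2.03 log units; beyond the scatter), so removing the chain and its oxygen from this aromatic carbon did not return the number towards that of compound 1. Among these three compounds, the number therefore does not follow group size: compound 1, with ethoxy, is lowest, while compound 3, with the smallest group, is highest. No evidence given bears on the reason for this result.

On these data alone, what a methoxy or propoxy group would give on this aromatic carbon remains open. So does whether the oxygen or the chain attached to it accounts for the difference from methyl.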